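Methylating the Lactam Nitrogen of a Kinase Inhibitor Amide

This account rests on a few compounds, and the source may have more. Where it says the series, first, only, none or still open, it means among the compounds named here.

The three measured compounds share one core and differ only in the group on the amide-type nitrogen. Compound 1 `Cn1cc(CNC(=O)c2ccncc2Nc2cc(-c3ccc4ccn(C)c4c3)c3nccnc3c2)cn1` carries a (1-methyl-1H-pyrazol-4-yl)methyl group there and gives 159 nM in an assay for inhibition of 6-phosphofructo-2-kinase/fructose-2,6-bisphosphatase 3 (Homo sapiens), read by ADP-Glo, with a stated time of 2 h; on this read-out lower numbers stand for stronger inhibition and higher numbers for weaker inhibition. Compound 2 `CN1CCC(NC(=O)c2ccncc2Nc2cc(-c3ccc4ccn(C)c4c3)c3nccnc3c2)CC1` bears a 1-methylpiperidin-4-yl group and gives 38 nM. Compound 3 `Cn1ccc2ccc(-c3cc(Nc4cnccc4C(=O)NC4CCNC(=O)C4)cc4nccnc34)cc21`, with a 2-oxopiperidin-4-yl group, gives 69 nM; it stands second highest of the three, with a 2.3-fold lower number from compound 1 to compound 3 (0.36 log units; beyond the scatter) and a 1.8-fold higher number from compound 2 to compound 3 (0.26 log units; within the scatter).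

Compound 4 `CN1CCC(NC(=O)c2ccncc2Nc2cc(-c3ccc4ccn(C)c4c3)c3nccnc3c2)CC1=O` follows from compound 3 by a single change: methyl in place of hydrogen on an amide-type nitrogen in a ring. Among the measured compounds shown here, no measured step makes exactly this change, but two are informative. The step of a 1.8-fold higher number from compound 2 to compound 3 (0.26 log units; within the scatter) shows that exchanging the ring substituent pattern on this nitrogen-bearing ring leaves the read-out essentially unchanged, and the steps of a 4.2-fold lower number from compound 1 to compound 2 (0.62 log units; beyond the scatter) and a 2.3-fold lower number from compound 1 to compound 3 (0.36 log units; beyond the scatter) show that both piperidine variants sit in the same modest range. A single methyl on the ring amide nitrogen is therefore expected to move the number little, in no clear direction, and compound 4 is estimated to show a 1.2-fold lower number from compound 3 to compound 4 (0.06 log units; within the scatter). Compound 4 is thus expected to give 60 nM, with a range from 25 nM to 150 nM.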

Compound 4, half-maximal inhibitory concentration: 41 nM
Compound 4: the middle estimate sits 1.5-fold (0.17 log units) above what was measured; the range from low to high includes it.
By their numbers in this assay, from the lowest: compounds 2, 4 and 3 (each within the scatter of the next); then compound 1.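

In this assay, methyl in place of hydrogen on the amide-type nitrogen in the ring gives a 1.7-fold lower number from compound 3 to compound 4 (0.23 log units; within the scatter), so at this position the amide hydrogen of compound 3 is not needed to keep the number in this range, and the position accepts a methyl group. With the methyl in place, the carbonyl of the 1-methyl-2-oxopiperidin-4-yl group also leaves the read-out within the scatter of the 1-methylpiperidin-4-yl group, with a 1.1-fold higher number from compound 2 to compound 4 (0.03 log units; within the scatter), while the step from the pyrazole-bearing amide, a 3.9-fold lower number from compound 1 to compound 4 (0.59 log units; beyond the scatter), stays beyond the scatter, as the steps to compound 2 and compound 3 already did. Nothing given here explains why these changes have such small effects on the read-out.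

The compounds shown leave open how this assay would respond to a larger group on this ring nitrogen, such as an ethyl group, a longer chain or a chain ending in a carboxylic acid. They also leave open what the plain piperidin-4-yl group, with hydrogen on the ring nitrogen and no carbonyl, would give on the amide-type nitrogen of the shared core.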